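This account rests on a few compounds, and the source may have more. Where it says the series, first, only, none or still open, it means among the compounds named here.

Compound 1 `N#Cc1cnc(NCc2cnccc2C(F)(F)F)cc1NC[C@H]1C[C@@H](O)C1` is tested in an assay on isolated protein for inhibition of protein kinase C theta type (Homo sapiens), read by TR-FRET, with a stated time of 2 h (on this read-out higher numbers stand for weaker inhibition and lower numbers for stronger inhibition), where compound 1 gives 300 nM, the highest of the two numbers in hand. The other measured compound, compound 2 `CC(C)(F)c1ncncc1CNc1cc(N[C@H]2CC[C@@H](O)CC2)c(C#N)cn1`, gives in this assay a value of 32 nM, a gap beyond the usual scatter. Compound 3 `CC1(C)[C@@H](C(N)=O)C[C@H]1Nc1cc(NCc2cnccc2C(F)(F)F)ncc1C#N` differs from compound 1 in a single place: 3-carbamoyl-2,2-dimethylcyclobutyl in place of (3-hydroxycyclobutyl)methyl on a nitrogen on an aromatic ring. Among the measured compounds shown here, no measured pair isolates this exact change, so the expectation rests on compound 1 at 300 nM and on the direction compound 2 points to. A moderate step toward stronger inhibition is expected, a 3.3-fold lower number from compound 1 to compound 3 (0.52 log units; beyond the scatter) in this assay. Compound 3 is therefore expected to give 90 nM, with a likely range from 25 nM to 350 nM.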

Compound 3, half-maximal inhibitory concentration: 1.4 nM
The estimate for compound 3 lay 64-fold (1.81 log units) above the measured number; the measured number lies below the stated range.
By their numbers in this assay, from the lowest: compound 3; then compound 2; then compound 1.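

In this assay, putting 3-carbamoyl-2,2-dimethylcyclobutyl in place of (3-hydroxycyclobutyl)methyl on the nitrogen gives a 210-fold lower number from compound 1 to compound 3 (2.33 log units; beyond the scatter), a large step toward stronger inhibition. This shows that the group at this position can change the read-out greatly, which compound 2 could not show, as it differs from compound 1 in more than one place. On these data alone, whether the carbamoyl group, the two methyl groups or the loss of the hydroxyl drives the step stays open, as does whether a carboxylic acid or an amine in place of the carbamoyl would do as well. No independent measurement accounts for the size of this step.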